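Replacing chloro with hydrogen on compound 2

This account rests on a few compounds, and the source may have more. Where it says the series, first, only, none or still open, it means among the compounds named here.

Within the data shown here, compound 2 (`Clc1ccc(-c2cn3nc(-c4ccccc4)nc3s2)cc1`) holds the lower of the two numbers available so far. In a functional assay on MOLT-4 cells (Homo sapiens) for inhibition, read by sulforhodamine B assay, with a stated time of 48 h, tested at 10 uM (on this read-out lower numbers stand for less inhibition of growth and higher numbers for more inhibition of growth at the one concentration tested), compound 2 reaches only 8% of inhibition, whereas compound 1 (`COc1ccc(-c2nc3sc(-c4ccccc4)cn3n2)cc1`) reaches 49% in the same test, a gap well beyond the usual scatter.

Compound 3 (`c1ccc(-c2nc3sc(-c4ccccc4)cn3n2)cc1`) has yet to be measured. The change from compound 2 (hydrogen in place of chloro on an aromatic carbon) puts hydrogen in place of chloro on an aromatic carbon, and the rest of the structure stays as it is. Among the measured compounds shown here, no pair of measured compounds shows this change on its own, so the data offer no direct precedent for it. For the measured compounds named here, the expectation therefore rests on compound 2 at 8% and compound 1 at 49% as the only two numbers in hand, and it leans towards the lower one. A modest rise in growth inhibition is expected, an estimated a number 12 percentage points higher from compound 2 to compound 3 (beyond the scatter) in this assay with real uncertainty about its size. The estimate for compound 3 is 20% with an expected range from 3% to 45% on this read-out.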

Compound 3, percent growth inhibition at one concentration: 11%
Beside the measured number, compound 3's estimate is 9 percentage points above it; the range from low to high includes it.
By their numbers in this assay, from the lowest: compounds 2 and 3 (each within the scatter of the next); then compound 1.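

In this assay, chloro and hydrogen on this aromatic carbon cannot be told apart, with a number 3 percentage points higher from compound 2 to compound 3 (within the scatter), so the 4-chlorophenyl to phenyl exchange shows that chloro at this place is not what holds compound 2 low: the unsubstituted compound 3 sits at the same level. Compound 3 also gives the first single-change reading for methoxy, with a number 38 percentage points lower from compound 1 to compound 3 (beyond the scatter), so among these three compounds only compound 1 stands clear of the others, and that step concerns the phenyl group at the other place on the shared core, not the one that carries chloro in compound 2. No measurement shown here accounts for either step.

From the compounds shown here alone, it remains open whether any other group on the aromatic carbon that carries chloro in compound 2, such as methoxy, an amine or a carboxylic acid, would lift the number above that of compound 3. Going by these compounds, it is equally open whether chloro in place of methoxy on the phenyl group of compound 1 would keep any of that compound's inhibition, or whether a longer alkoxy chain there would add to it.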